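The source may report more compounds than this note shows. Statements on the series, on what has been measured and on what is new or still open speak of the compounds shown alone.

Of the compounds shown here, three sharing one core have been tested in an ADME assay on Vero cells (Chlorocebus sabaeus) for cytotoxicity, read by MTT assay, with a stated time of 48 h; a higher number here means a weaker inhibitor, a lower number a stronger inhibitor. Compound 1 `O=C(OC1CCC(CN2CCN(c3cc(=O)c4cc(C(F)(F)F)cc([N+](=O)[O-])c4s3)CC2)CC1)c1cccs1` carries a (thiophen-2-yl)carbonyl on an oxygen on a saturated carbon; in this assay compound 1 reaches only the limit of > 64 ug/mL, which is a limit and not a number. Compound 2 `CS(=O)(=O)OC1CCC(CN2CCN(c3cc(=O)c4cc(C(F)(F)F)cc([N+](=O)[O-])c4s3)CC2)CC1` bears methylsulfonyl at that oxygen, and in this assay compound 2 likewise stops at the limit of > 64 ug/mL. Compound 3 `O=C(OC1CCC(CN2CCN(c3cc(=O)c4cc(C(F)(F)F)cc([N+](=O)[O-])c4s3)CC2)CC1)c1ccncc1` carries (pyridin-4-yl)carbonyl there; in this assay compound 3 also gives the limit of > 64 ug/mL. All three values thus sit at the limit of > 64 ug/mL in this assay, at which 3 of the 3 values shown sit, so the steps a step that the two limits leave unreadable from compound 1 to compound 2, a step that the two limits leave unreadable from compound 1 to compound 3 and a step that the two limits leave unreadable from compound 2 to compound 3 cannot be read: each could be flat or could run either way. Compound 3 stands with the other two at the limit, and nothing shown separates it from them.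

Compound 4 `Cc1cccc(C(=O)OC2CCC(CN3CCN(c4cc(=O)c5cc(C(F)(F)F)cc([N+](=O)[O-])c5s4)CC3)CC2)c1` differs from compound 3 in one place: 3-methylphenyl in place of pyridin-4-yl on a carbonyl carbon. Within the data shown here, none of the measured steps has a readable size, so none gives a direction for this change; what they do show is that exchanging the group on that oxygen three ways left every value at the limit. Compound 4 is therefore expected to remain at the limit too, with an estimated step that the limit leaves unreadable from compound 3 to compound 4. The estimated value of compound 4 is 80 ug/mL, spanning 40 ug/mL to 160 ug/mL.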

Compound 4, half-maximal inhibitory concentration: > 64 ug/mL
Compound 4: no number, only a limit (the forecaster's own chance of this, stated with the estimate: 80%); the middle value is on the limit's open side.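

In this assay compound 4 gives > 64 ug/mL, which is a limit and not a number. The steps from compound 1, compound 2 and compound 3 to compound 4 cannot be read, because all four compounds share one limit: the limit of > 64 ug/mL in this assay, at which 4 of the 4 values shown sit.

The compounds shown leave open whether exchanging the group on that oxygen changes this read-out at all.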